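Compound 3: Part of the Way Back Toward Compound 1?

The source may hold more compounds than are shown below. What is called first, only, known or untested is meant among the compounds shown, and "the series" means these compounds.

Of the compounds shown here, two sharing one core have been measured in a functional assay on BT-474 cells (Homo sapiens) for inhibition, read by CellTiter-Glo, with a stated time of 72 h; a lower number here means a stronger inhibitor, a higher number a weaker inhibitor. Compound 1 `Cc1cc(Nc2ncnc3cc(O)c(NC(=O)/C=C/[C@H]4CCCN4C)cc23)ccc1Oc1ccn2ccnc2c1` gives 4.63 nM, and compound 2 `Cc1cc(Nc2ncnc3cc(O)c(NC(=O)/C=C/[C@H]4CCCN4C)cc23)ccc1Oc1cnn2cnnc2c1` gives 20.8 nM, so compound 2 stands as the higher, weaker number of the two. Compound 3 `Cc1cc(Nc2ncnc3cc(O)c(NC(=O)/C=C/[C@H]4CCCN4C)cc23)ccc1Oc1ccn2cnnc2c1`, not yet measured, differs from compound 2 in one place, on an oxygen on an aromatic ring: a group of 9 heavy atoms (6 carbon, 3 nitrogen; one five-membered aromatic ring with 3 hetero atoms, one six-membered aromatic ring with 1 hetero atom) in place of a group of 9 heavy atoms (5 carbon, 4 nitrogen; one five-membered aromatic ring with 3 hetero atoms, one six-membered aromatic ring with 2 hetero atoms), on an oxygen on an aromatic ring. Its five-membered aromatic ring with 3 hetero atoms matches the count in compound 2, while its six-membered aromatic ring with 1 hetero atom matches the count in compound 1. Going by the values given here, only one measured step bears on this change, a 4.5-fold higher number from compound 1 to compound 2 (0.65 log units; beyond the scatter). That modest step altered both rings at once, so the data do not show how much of it belongs to either ring. Undoing only the six-membered part should recover some of that step, though probably not all of it. A step of a 2.2-fold lower number from compound 2 to compound 3 (0.34 log units; beyond the scatter) is therefore expected, toward a lower number. Compound 3 is estimated at 9.5 nM, with an expected range from 4 nM to 25 nM.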

Compound 3, half-maximal inhibitory concentration: 26.8 nM
The estimate for compound 3 lay 2.8-fold (0.45 log units) below the measured number, and the stated range ends below it.
By their numbers in this assay, from the lowest: compound 1; then compounds 2 and 3 (each within the scatter of the next).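

The extra hetero atom in the six-membered aromatic ring turns out not to be what separates these compounds: in this assay, the change on this oxygen on an aromatic ring gives a 1.3-fold higher number from compound 2 to compound 3 (0.11 log units; within the scatter), so going from a six-membered aromatic ring with 2 hetero atoms to one with 1 hetero atom leaves no readable difference between compound 2 and compound 3. Going by these compounds alone, the gap instead appears with the change that keeps the six-membered aromatic ring with 1 hetero atom and replaces the five-membered aromatic ring with 2 hetero atoms by one with 3 hetero atoms, which gives a 5.8-fold higher number from compound 1 to compound 3 (0.76 log units; beyond the scatter), a step beyond the scatter and about the size of the one seen earlier between compound 1 and compound 2. Nothing given here explains this difference.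

On these data alone, what stays open is whether the six-membered ring would also make no readable difference alongside the five-membered aromatic ring with 2 hetero atoms of compound 1, since the comparison here rests on the five-membered aromatic ring with 3 hetero atoms alone. As far as these compounds go, it is also open how a methyl group or an amine placed on the group on this oxygen would read in this assay.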